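This account rests on a few compounds, and the source may have more. Where it says the series, first, only, none or still open, it means among the compounds named here.

Compound 1 `CCOc1ccc(Nc2c(C(=O)c3cc(OC)c(OC)c(OC)c3)sc3ccccc23)cc1`: 500 nM
Compound 2 `COc1cc(C(=O)c2sc3cc(C)ccc3c2Nc2ccc(C)cc2)cc(OC)c1OC`: 1900 nM

For the measured compounds named here, only two compounds have been measured so far. In a functional assay on HL-60 cells (Homo sapiens) for antiproliferative activity, read by MTT assay, with a stated time of 72 h (on this read-out lower numbers stand for stronger inhibition and higher numbers for weaker inhibition), compound 2 gives 1900 nM, the higher of the two numbers. Compound 1 gives 500 nM, and the gap between them lies beyond the usual scatter, so compound 2 is the weaker inhibitor of this pair.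

The next compound is compound 3 `CCOc1ccc(Nc2c(C(=O)c3cc(OC)c(OC)c(OC)c3)sc3cc(C)ccc23)cc1`. Compared with compound 2, it has ethoxy in place of methyl on an aromatic carbon, so 4-methylphenyl becomes 4-ethoxyphenyl. Going by the values given here, no measured pair differs in just one place, which leaves the size of this change without a direct precedent. Among the compounds with values here, the only guide is that the 4-ethoxyphenyl group is also found in compound 1, which gives 500 nM. A move toward stronger inhibition in this assay therefore seems likely, probably beyond the scatter, though this rests on a single compound. The expected change is a 3.2-fold lower number from compound 2 to compound 3 (0.50 log units; beyond the scatter). The estimated value for compound 3 is 600 nM, within a range from 200 nM to 1800 nM.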

Compound 3, half-maximal inhibitory concentration: 4000 nM
Beside the measured number, compound 3's estimate is 6.7-fold (0.82 log units) below it; the measured number lies above the stated range.
By their numbers in this assay, from the lowest: compound 1; then compound 2; then compound 3.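

In this assay, replacing 4-methylphenyl with 4-ethoxyphenyl on the methyl-bearing core gives a 2.1-fold higher number from compound 2 to compound 3 (0.32 log units; beyond the scatter). On this core, then, ethoxy on an aromatic carbon of the six-membered ring, para to a large group, gives weaker inhibition than methyl in the same place, so the change does not bring the gain that compound 1 alone had suggested. The second step holds 4-ethoxyphenyl fixed and places methyl instead of hydrogen on an aromatic carbon of the core, giving an 8.0-fold higher number from compound 1 to compound 3 (0.90 log units; beyond the scatter), which shows that this one small addition can also weaken inhibition beyond the usual scatter.

As far as these compounds go, it remains open how the swap from methyl to ethoxy behaves on the core without its methyl, and whether a propoxy chain, a hydroxyl group or an amine in the same place would weaken inhibition as well. No supporting measurement is available to explain either loss, so the two steps stand as observations only.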